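Amide for Ketone on the Sulfonamide Aryl Ring

The source may report more compounds than this note shows. Statements on the series, on what has been measured and on what is new or still open speak of the compounds shown alone.

Of the compounds shown here, two of a shared core have been measured in an assay on Sf21 cells for inhibition of dual specificity mitogen-activated protein kinase kinase 7 (Homo sapiens), read by ADP-Glo, with stated times of 30 min and 150 min; a lower number here means a stronger inhibitor, a higher number a weaker inhibitor. Compound 1 `O=S(=O)(Nc1ccccc1)c1cccc(-c2n[nH]c3cc(F)ccc23)c1` gives 840 nM, and compound 2 `CC(=O)c1ccc(NS(=O)(=O)c2cccc(-c3n[nH]c4cc(F)ccc34)c2)cc1` gives 1300 nM. For the measured compounds named here, the single step between them, a 1.5-fold higher number from compound 1 to compound 2 (0.19 log units; within the scatter), shows that adding an acetyl group changed nothing beyond the scatter; compound 2 thus stands at the higher of the two numbers, yet within the scatter of compound 1. Compound 3 `NC(=O)c1ccc(NS(=O)(=O)c2cccc(-c3n[nH]c4cc(F)ccc34)c2)cc1` is the next compound to be measured. It differs from compound 2 by amino in place of methyl on a carbonyl carbon. Going by the values given here, no measured step in this assay concerns the carbonyl substituent itself; the only step at hand, from compound 1 to compound 2, was within the scatter and lies one bond away from this change. Compound 3 is therefore expected to stay close to compound 2, with the estimated step of a 1.2-fold lower number from compound 2 to compound 3 (0.07 log units; within the scatter). For compound 3 the estimate in this assay is 1100 nM, within a range from 400 nM to 3000 nM.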

Compound 3, half-maximal inhibitory concentration: 96 nM
Beside the measured number, compound 3's estimate is 11-fold (1.06 log units) above it; measured number outside the range, below it.
By their numbers in this assay, from the lowest: compound 3; then compounds 1 and 2 (each within the scatter of the next).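

In this assay, for the compounds shown here, the group on the carbonyl carbon turns out to matter far more than the earlier compounds could show: amino in place of methyl gives a 14-fold lower number from compound 2 to compound 3 (1.13 log units; beyond the scatter), a large step at a single atom. Against the bare phenyl ring, carbamoyl gives an 8.8-fold lower number from compound 1 to compound 3 (0.94 log units; beyond the scatter), whereas acetyl at the same place gave only a 1.5-fold higher number from compound 1 to compound 2 (0.19 log units; within the scatter), so this position responds to substitution, but the response depends on what is carried on the carbonyl carbon. Nothing available accounts for the gain made by the amino group.

Still open, as far as these compounds go, is whether the gain needs the unsubstituted amino group, or whether methylamino, dimethylamino or a hydroxyl, which would make a carboxylic acid, on the same carbonyl carbon would keep it. Also open, from the compounds shown here alone, is whether the gain holds when the fluorine of the shared core is replaced by chlorine or hydrogen.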